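A few compounds are considered here, and "the series" means these few. Any claim that something is new, unique, unknown or untested is made for them only; others in the source may bear on it.

Three compounds of the series have numbers in an ADME assay on L02 cells (Homo sapiens) for cytotoxicity, read by MTT assay, with a stated time of 48 h; on this read-out higher numbers stand for weaker inhibition and lower numbers for stronger inhibition. Compound 1 `O=C1O[C@@H](CO)CN1c1ccc(-n2cc(-c3ccccn3)cn2)c(F)c1` gives 59 ug/mL. Compound 2 `CCN1CCN(C[C@H]2CN(c3ccc(-n4cc(-c5ccccn5)cn4)c(F)c3)C(=O)O2)CC1` gives 99 ug/mL. For compound 3 `O=C1CCC(=O)N1C[C@H]1CN(c2ccc(-n3cc(-c4ccccn4)cn3)c(F)c2)C(=O)O1` the result is > 400 ug/mL, which is a limit of the assay and not a number. Between the two plain numbers there is a 1.7-fold higher number from compound 1 to compound 2 (0.22 log units; within the scatter). The other two steps, an at least 6.7-fold higher number from compound 1 to compound 3 (0.83 log units; beyond the scatter) and an at least 4.0-fold higher number from compound 2 to compound 3 (0.60 log units; beyond the scatter), both end at the limit of the limit of > 400 ug/mL in this assay, at which 1 of the 3 values shown sits, so for compound 3 only a range is known, and it sits at the top of the numbers shown.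

Compound 4 `O=C1CNC(=O)N1C[C@H]1CN(c2ccc(-n3cc(-c4ccccn4)cn3)c(F)c2)C(=O)O1` differs from compound 3 in one place: 2,5-dioxoimidazolidin-1-yl in place of 2,5-dioxopyrrolidin-1-yl on a saturated chain carbon bound to a saturated ring carbon. Among the compounds with values here, no measured step changes this ring; the two steps that reach compound 3 exchange the whole group on the same saturated chain carbon, and both pass beyond the scatter toward the limit. Within the data shown here, with the ring kept and only one ring atom exchanged, the step of a number no higher from compound 3 to compound 4 (the limit leaves the size open) is expected to stay within the scatter, with no clear direction. Compound 4 is accordingly expected to give about 400 ug/mL in this assay, with a range from 200 ug/mL to 800 ug/mL, and a fair chance that the result is again reported only as a limit.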

Compound 4, half-maximal inhibitory concentration: > 400 ug/mL
Compound 4: a limit, no number; the forecaster's own chance of this, stated with the estimate: 65%; the middle value sits exactly at the limit.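

The 2,5-dioxoimidazolidin-1-yl ring, with one hydrogen-bond donor where 2,5-dioxopyrrolidin-1-yl has none, leaves compound 4 at the same limit as compound 3 in this assay, so on a saturated chain carbon bound to a saturated ring carbon the result is no longer confined to a single ring. Against the two other groups at this place, the new ring gives an at least 4.0-fold higher number from compound 2 to compound 4 (0.60 log units; beyond the scatter) and an at least 6.7-fold higher number from compound 1 to compound 4 (0.83 log units; beyond the scatter); among the four compounds, both five-membered dioxo rings reach the limit, while the hydroxy of compound 1 and the 4-ethylpiperazin-1-yl of compound 2 give plain numbers. The step between the two rings cannot be read, and any difference between them stays hidden because both results end at the same limit: the limit of > 400 ug/mL in this assay, at which 2 of the 4 values shown sit.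

The compounds shown leave open whether a single carbonyl, as in a pyrrolidin-2-one ring, is enough to reach this limit. Going by these compounds, it is equally open whether an open-chain acetamide or a morpholin-4-yl group on the same carbon would reach it, or would instead give a plain number like compound 1 and compound 2.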